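Compound 3 trades furan-2-yl for 3-methyl-1H-pyrazol-4-yl

A few compounds are considered here, and "the series" means these few. Any claim that something is new, unique, unknown or untested is made for them only; others in the source may bear on it.

Three related compounds come before this step in an ADME assay on L02 cells (Homo sapiens) for antiproliferative activity, read by CCK-8 assay, with a stated time of 6 days (a higher number here means a weaker inhibitor, a lower number a stronger inhibitor), and only one of them has a usable number. Compound 1 (`N#Cc1ccc(N2CCc3cc(-c4cncnc4)ccc32)cc1C(F)(F)F`) has "not determined" (no result reported) as its entry. Compound 2 (`N#Cc1ccc(N2CCCc3c(-c4cccnc4)cccc32)cc1C(F)(F)F`) gives 10500 nM as its half-maximal inhibitory concentration. Compound 3 (`CCN(c1ccc(C#N)c(Cl)c1)c1cc(-c2ccco2)ccc1C`) has "not determined" (no result reported) as its entry, which leaves its standing unknown and means it cannot be ranked against compound 2.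

Compound 4 (`CCN(c1ccc(C#N)c(Cl)c1)c1cc(-c2c[nH]nc2C)ccc1C`) differs from compound 3 in one place. There, 3-methyl-1H-pyrazol-4-yl stands in place of furan-2-yl on an aromatic carbon (3-methyl-1H-pyrazol-4-yl in place of furan-2-yl on an aromatic carbon) of a six-membered aromatic ring of carbon only. The rest of the molecule stays the same.

Among the compounds with values here, no measured pair shows what such a swap does, and compound 3 offers no starting number. The expectation is therefore no step beyond the usual scatter between compound 3 and compound 4 in this assay and no particular direction. Within the data shown here, the only numerical guide is compound 2 at 10500 nM on a different core, so a value near that level is expected. Compound 4 is estimated at 10000 nM with an expected range from 3000 nM to 30000 nM around it.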

Compound 4, half-maximal inhibitory concentration: 5780 nM
The estimate for compound 4 lay 1.7-fold (0.24 log units) above the measured number; the measured number falls inside the stated range.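

Within the data shown here, compound 4 gives 5780 nM in this assay and compound 3 has no single number there, so no step between the two can be read. The compounds shown leave open what putting 3-methyl-1H-pyrazol-4-yl in place of furan-2-yl does to this value. Nothing shown offers an explanation for the number of compound 4.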